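Moving the fluorine on the benzyl group: compound 3

A few compounds are considered here, and "the series" means these few. Any claim that something is new, unique, unknown or untested is made for them only; others in the source may bear on it.

Within the data shown here, in an assay on CHO cells for displacement of a labelled ligand from D(4) dopamine receptor (Homo sapiens), read by radioligand binding (on this read-out lower numbers stand for stronger inhibition and higher numbers for weaker inhibition), compound 2 `COc1ccccc1N1CCN(CCCNC(=O)NN(Cc2ccccc2F)c2ccc(F)cc2)CC1` gives 3.6 nM, the lowest of the two numbers so far; compound 1 `COc1ccccc1N1CCN(CCNC(=O)NN(Cc2ccccc2)c2ccc(F)cc2)CC1` gives 9 nM, a higher number that lies beyond the scatter. Compound 3 `COc1ccccc1N1CCN(CCCNC(=O)NN(Cc2cccc(F)c2)c2ccc(F)cc2)CC1` remains to be measured and differs from compound 2 by 3-fluorophenyl in place of 2-fluorophenyl on a saturated chain carbon bound to a nitrogen on an aromatic ring. Among the measured compounds shown here, no measured pair isolates this difference, so its size cannot be read from the series. The expectation is a shift of no more than the scatter, with a slight lean toward a higher number. Compound 3 is therefore estimated at 5 nM, between 1.5 nM and 15 nM. The expected step is then a 1.4-fold higher number from compound 2 to compound 3 (0.14 log units; within the scatter).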

Compound 3, inhibition constant: 3.8 nM
For compound 3 the middle estimate is 1.3-fold (0.12 log units) above the measured one; measured number inside the range.
By their numbers in this assay, from the lowest: compounds 2 and 3 (each within the scatter of the next); then compound 1.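

In this assay, 3-fluorophenyl in place of 2-fluorophenyl on a saturated chain carbon bound to a nitrogen on an aromatic ring gives a 1.1-fold higher number from compound 2 to compound 3 (0.02 log units; within the scatter), so this pair, the first to isolate a single change, does not separate the two fluorine placements. The read-out therefore shows tolerance of this particular swap, and nothing more general about the benzyl group. No available evidence bears on this result.

On these data alone, whether a chlorine or a methoxy group on the benzyl ring would behave likewise remains open. So does the effect of a longer chain.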